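The compounds below may be only part of what the source reports. "The series", "measured", "known", "first", "only" and "open" are said of these compounds alone.

Within the data shown here, the three compounds measured so far share one core and differ only in the aryl group on the sulfonyl sulfur. Compound 1 `N#CCCN(Cc1cccs1)S(=O)(=O)c1cccc(F)c1` carries a 3-fluorophenyl there, compound 2 `N#CCCN(Cc1cccs1)S(=O)(=O)c1ccc(F)cc1` a 4-fluorophenyl, and compound 3 `N#CCCN(Cc1cccs1)S(=O)(=O)c1ccc(Br)cc1` a 4-bromophenyl. In an ADME assay on MDCK cells (Canis lupus familiaris) for cytotoxicity, read by MTT assay, with a stated time of 24 h (on this read-out lower numbers stand for higher toxicity in this test and higher numbers for lower toxicity in this test), compound 1 gives only a limit, > 205000 nM. In this assay compound 2 likewise reaches only a limit, > 205000 nM. In this assay compound 3 also stops at a limit, > 173000 nM. With every value a limit, the steps among them stay unreadable: a step that the two limits leave unreadable from compound 1 to compound 2, a step that the two limits leave unreadable from compound 1 to compound 3 and a step that the two limits leave unreadable from compound 2 to compound 3. Compound 2 thus stands at the limit of > 205000 nM in this assay, at which 2 of the 3 values shown sit, and nothing measured sets it apart from its neighbours.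

Compound 4 `Cc1ccc(S(=O)(=O)N(CCC#N)Cc2cccs2)cc1` differs from compound 2 in one place: methyl in place of fluoro on an aromatic carbon. Among the measured compounds shown here, none of the measured steps offers a readable size that bears on this change, since each runs between two limits. The only guidance is that no compound so far has shown a measurable half-maximal cytotoxic concentration in this assay, so the expectation for compound 4 is that the step of an at least 1.0-fold lower number from compound 2 to compound 4 (0.01 log units; that floor lies within the scatter) stays within the scatter, most likely with the read-out again reported only as a limit. Compound 4 is therefore estimated at 200000 nM, with a range from 60000 nM to 500000 nM.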

Compound 4, half-maximal cytotoxic concentration: 127000 nM
Compound 4: middle estimate off by 1.6-fold (0.20 log units), on the high side, within the range that was stated.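

Among the four compounds, only compound 4 gives a measured number rather than a limit in this assay, so the 4-methylphenyl group gives this position its first readable value. Each comparison can be bounded from one side only, as an at least 1.6-fold lower number from compound 2 to compound 4 (0.20 log units; that floor lies within the scatter), as an at least 1.3-fold lower number from compound 3 to compound 4 (0.13 log units; that floor lies within the scatter) and as an at least 1.6-fold lower number from compound 1 to compound 4 (0.20 log units; that floor lies within the scatter), so methyl in place of fluoro or bromo is not shown to move the read-out beyond the scatter, although the real steps may be larger than these floors. Compound 1 and compound 2 remain at the same limit: the limit of > 205000 nM in this assay, at which 2 of the 4 values shown sit.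

Going by these compounds, how far the read-outs of compound 1, compound 2 and compound 3 lie beyond their limits stays open, and with it the real size of all three steps. Also open, on these data alone, is whether an ethyl group, an amine or a carboxylic acid in place of the methyl of compound 4 would bring the number down further or return it to a limit.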